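Swapping the sulfonamide substituent on a kinase-like scaffold

This account rests on a few compounds, and the source may have more. Where it says the series, first, only, none or still open, it means among the compounds named here.

Measured compounds in a functional assay on K562 cells (Homo sapiens) for antiproliferative activity, read by CCK-8 assay, with a stated time of 72 h; a lower number here means a stronger inhibitor of growth, a higher number a weaker inhibitor of growth:
compound 1 `CCCNS(=O)(=O)c1ccc(Nc2ncc3c(n2)N(C2CCCC2)[C@H](CC)C(=O)N3C)cc1` gives 548 nM
compound 2 `CC[C@@H]1C(=O)N(C)c2cnc(Nc3ccc(S(N)(=O)=O)cc3)nc2N1C1CCCC1` gives 470 nM
compound 3 `CC[C@@H]1C(=O)N(C)c2cnc(Nc3ccc(S(=O)(=O)NCC(C)C)cc3)nc2N1C1CCCC1` gives 705 nM

Compound 3 carries the highest of the three numbers, yet every step leading to it is within the scatter: a 1.3-fold higher number from compound 1 to compound 3 (0.11 log units; within the scatter) and a 1.5-fold higher number from compound 2 to compound 3 (0.18 log units; within the scatter). The three compounds are therefore indistinguishable in this assay.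

Compound 4 `CC[C@@H]1C(=O)N(C)c2cnc(Nc3ccc(S(=O)(=O)Nc4ccccc4)cc3)nc2N1C1CCCC1` is the next variation at the same position. The change is phenyl in place of isobutyl on a sulfonamide nitrogen.

Two measured steps alter the same sulfonamide nitrogen. The step of a 1.2-fold lower number from compound 1 to compound 2 (0.07 log units; within the scatter) removes a propyl, and the step of a 1.5-fold higher number from compound 2 to compound 3 (0.18 log units; within the scatter) adds an isobutyl; neither moves the number beyond the scatter. Within the data shown here, compound 4 instead places a phenyl there, a ring rather than a chain, and no measured compound carries a ring at this nitrogen, so the data give no direct guidance on that. Given how little the hydrogen, propyl and isobutyl variants differ, the expectation for compound 4 in this assay is a step of about a 1.0-fold lower number from compound 3 to compound 4 (0.00 log units; within the scatter), that is, nothing beyond the scatter. Compound 4 is estimated at 700 nM, in the range 300 nM to 1600 nM.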

Compound 4, concentration for 50% growth inhibition: 4180 nM
Beside the measured number, compound 4's estimate is 6.0-fold (0.78 log units) below it, and the stated range ends below it.
By their numbers in this assay, from the lowest: compounds 2, 1 and 3 (each within the scatter of the next); then compound 4.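

Compound 4 shows that this sulfonamide nitrogen is not indifferent to what it carries in this assay: phenyl in place of isobutyl gives a 5.9-fold higher number from compound 3 to compound 4 (0.77 log units; beyond the scatter) and phenyl in place of hydrogen gives an 8.9-fold higher number from compound 2 to compound 4 (0.95 log units; beyond the scatter), while phenyl in place of propyl gives a 7.6-fold higher number from compound 1 to compound 4 (0.88 log units; beyond the scatter) as well. Among these compounds, the hydrogen, propyl and isobutyl compounds all lie within the scatter of one another, so this is the first change at the nitrogen to move the number beyond the scatter, and it makes compound 4 the weakest inhibitor of growth of the four. Nothing in the available data gives a reason for this loss of activity.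

On these data alone, whether any ring on this nitrogen has the same result remains open: cyclohexyl would test a saturated ring in place of the aromatic one, and benzyl would test a phenyl held one carbon further out. Also unresolved is whether a phenyl bearing a further group, such as a methoxy group or a fluorine atom, would give a number closer to those of the chain compounds.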